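The source may report more compounds than this note shows. Statements on the series, on what has been measured and on what is new or still open speak of the compounds shown alone.

In an assay on isolated protein for inhibition of Aromatase (Homo sapiens), read by fluorescence, using NADPH, with a stated time of 30 min, tested at 50 uM (on this read-out lower numbers stand for less inhibition and higher numbers for more inhibition at the one concentration tested (going by the name of the read-out)), three compounds built on one shared core have been measured. Among the measured compounds shown here, compound 1 `N#Cc1ccc2[nH]c(-c3ccccc3)cc2c1` gives 82.3% and compound 3 `Nc1ccc2[nH]c(-c3ccccc3)cc2c1` gives 41.4%; the single recorded step, a number 40.9 percentage points lower from compound 1 to compound 3 (beyond the scatter), is the only one-place change among the measured compounds. Compound 2 `C#CCn1c(-c2ccccc2)cc2ccccc21` gives 26.3% and stands lowest of the three numbers: the value of compound 3 lies nearest to it and the value of compound 1 lies furthest from it, both gaps beyond the scatter.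

Compound 4 `COCn1c(-c2ccccc2)cc2ccccc21` differs from compound 2 in one place: methoxy in place of ethynyl on a saturated chain carbon bound to an aromatic nitrogen. For the measured compounds named here, no measured step concerns this part of the molecule. The step from compound 1 to compound 3 sits on an aromatic carbon of the core, not on the saturated chain carbon bound to the aromatic nitrogen, and it cannot be carried over to the new change. With nothing in the measured numbers to push the value either way, the author expects no step beyond the scatter in this assay, so that a number 1.3 percentage points lower from compound 2 to compound 4 (within the scatter) is the expected change. Compound 4 is therefore estimated at 25% in this assay, with a range from 10% to 45%.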

Compound 4, a percentage reported as inhibition, at one concentration (the size of the read-out at that concentration, not a potency): 20.2%
Compound 4: middle estimate off by 4.8 percentage points, on the high side; the range from low to high includes it.
By their numbers in this assay, from the lowest: compounds 4 and 2 (each within the scatter of the next); then compound 3; then compound 1.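

The exchange of methoxy for ethynyl on a saturated chain carbon bound to an aromatic nitrogen gives, in this assay, a number 6.1 percentage points lower from compound 2 to compound 4 (within the scatter), and this is the only step shown at this position. Propargyl and methoxymethyl therefore cannot be told apart in this read-out, even though a triple bond leaves and a hydrogen-bond acceptor enters, so the triple bond is not needed for a value at this level. Nothing available explains why the two groups read alike.

From the compounds shown here alone, what remains open is whether any group at this place can move the number beyond the scatter, for instance an amine, a carboxylic acid or a longer chain on the same carbon, since two groups of equal heavy-atom count give only a narrow view of the position. Also open, going by these compounds, is how a substituent on the aromatic nitrogen would read together with the nitrile on the aromatic carbon of compound 1, and whether the step seen here would hold in that setting.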